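Swapping the benzodioxinylmethyl arm for a methoxybenzyl group

The source may hold more compounds than are shown below. What is called first, only, known or untested is meant among the compounds shown, and "the series" means these compounds.

Two bis(trifluoromethyl)benzenesulfonamides carrying a basic amine have been tested in a functional assay on Capan-2 cells (Homo sapiens) for inhibition, read by MTT assay, with a stated time of 72 h; a higher number here means a weaker inhibitor of growth, a lower number a stronger inhibitor of growth. Among the measured compounds shown here, compound 1 `CC(C)(C)c1ccc(CNCCNS(=O)(=O)c2cc(C(F)(F)F)cc(C(F)(F)F)c2)cc1` gives 13000 nM, while compound 2 `O=S(=O)(NCCCNCC1COc2ccccc2O1)c1cc(C(F)(F)F)cc(C(F)(F)F)c1` gives 2500 nM; of the two numbers, the one for compound 2 is the lower, and the gap to compound 1 lies beyond the usual scatter, so compound 2 stands as the stronger inhibitor of growth in this assay among the compounds measured so far.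

Compound 3 `COc1ccc(CNCCCNS(=O)(=O)c2cc(C(F)(F)F)cc(C(F)(F)F)c2)cc1` has not yet been measured. Against compound 2 it shows one change (4-methoxyphenyl in place of 2,3-dihydro-1,4-benzodioxin-2-yl on a saturated chain carbon bound to an amine nitrogen). The change keeps the sulfonamide, the chain and the amine and alters only the group hung on the saturated chain carbon bound to the amine nitrogen.

For the measured compounds named here, no step between measured compounds speaks directly to this change. Because the two measured values are 2500 nM for compound 2 and 13000 nM for compound 1, a modest loss is judged more likely than a gain. The author expects compound 3 to come in around 4500 nM, with a plausible range from 1500 nM to 13000 nM. The expected step is a 1.8-fold higher number from compound 2 to compound 3 (0.26 log units; within the scatter), within or just beyond the scatter.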

Compound 3, concentration for 50% growth inhibition: 2400 nM
Compound 3: middle estimate off by 1.9-fold (0.27 log units), on the high side, and the stated range covers the measured number.
By their numbers in this assay, from the lowest: compounds 3 and 2 (each within the scatter of the next); then compound 1.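

In this assay, replacing the (2,3-dihydro-1,4-benzodioxin-2-yl)methyl arm with 4-methoxybenzyl gives a 1.0-fold lower number from compound 2 to compound 3 (0.02 log units; within the scatter), so the two arms cannot be told apart at this place on a saturated chain carbon bound to an amine nitrogen. The six-membered non-aromatic ring with 2 hetero atoms leaves, the count of hydrogen-bond acceptors in the group goes from 2 to 1, and the group carries fewer heavy atoms, yet the number stays within the scatter, so for this pair the level of growth inhibition does not depend on that ring. No measurement at hand bears on why the two arms read alike.

From the compounds shown here alone, whether the same level would hold with a plain benzyl group, a carboxylic acid or a second amine on this chain carbon remains open, since only these two arms are compared here. Compound 1 differs from compound 3 in both its chain and its arm, so the compounds shown do not separate what each of those two parts contributes, and a longer chain also remains untested among them.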